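This account rests on a few compounds, and the source may have more. Where it says the series, first, only, none or still open, it means among the compounds named here.

Measured so far:
compound 1 `Cc1nc(N2CCC(N3C(=O)CCC3=O)CC2)nc2ccc(NC(=O)/C=C/c3ccc(OC(F)(F)F)cc3)cc12` gives 35 nM
compound 2 `C/C(=C\C(=O)Nc1ccc2nc(N3CCC(O)CC3)nc(C)c2c1)c1ccc(Cl)cc1` gives 227 nM
compound 3 `C/C(=C\C(=O)Nc1ccc2nc(N3CCC(N4CCCC4=O)CC3)nc(C)c2c1)c1ccc(OC(F)(F)F)cc1` gives 39 nM

In a functional assay on CHO-K1 cells for antagonist activity at melanin-concentrating hormone receptor 1 (Homo sapiens), read by inositol phosphate accumulation, with stated times of 10 min and 45 min (on this read-out higher numbers stand for weaker inhibition and lower numbers for stronger inhibition), compound 1 gives the lowest number of the three. Compound 3 lies within the usual scatter of it, so no order between those two can be claimed; compound 2 stands beyond the scatter at a clearly higher number, meaning weaker inhibition.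

Compound 4 `Cc1nc(N2CCC(N3CCCC3=O)CC2)nc2ccc(NC(=O)/C=C/c3ccc(OC(F)(F)F)cc3)cc12` has not been measured. It differs from compound 1 in one place: 2-oxopyrrolidin-1-yl in place of 2,5-dioxopyrrolidin-1-yl on a saturated ring carbon. Compound 3 already carries a 2-oxopyrrolidin-1-yl group and gives 39 nM, close to compound 1. The step of a 1.1-fold higher number from compound 1 to compound 4 (0.04 log units; within the scatter) is therefore expected to stay within the scatter, in no clear direction. Compound 4 is expected to give about 38 nM, within a range from 15 nM to 90 nM.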

Compound 4, half-maximal inhibitory concentration: 12 nM
Compound 4: the middle estimate sits 3.2-fold (0.50 log units) above what was measured; the whole stated range lies above it.
By their numbers in this assay, from the lowest: compound 4; then compounds 1 and 3 (each within the scatter of the next); then compound 2.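

In this assay, swapping 2,5-dioxopyrrolidin-1-yl for 2-oxopyrrolidin-1-yl on this saturated ring carbon gives a 2.9-fold lower number from compound 1 to compound 4 (0.46 log units; beyond the scatter). So this position responds to the loss of a single carbonyl, and the second carbonyl is not needed for inhibition in this series. Nothing measured here accounts for the gain.

Still open, as far as these compounds go, is how far this position tolerates other groups, such as a simple amine or a carboxylic acid on the same ring carbon. From the compounds shown here alone, whether a six-membered lactam would do as well also remains unknown.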